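Swapping Chloro for Iodo on a Shared Core

A few compounds are considered here, and "the series" means these few. Any claim that something is new, unique, unknown or untested is made for them only; others in the source may bear on it.

Compound 1, `C/C(=N/NC(=S)Nc1ccccc1Cl)c1ccccn1`, gives 0.16 nM in a functional assay on MCF7 cells (Homo sapiens) for cytotoxicity, read by MTT assay, with a stated time of 48 h; on this read-out lower numbers stand for stronger inhibition and higher numbers for weaker inhibition.
Compound 2, `CC(=NNC(S)=Nc1ccccc1Cl)c1ccccn1`, gives 0.16 nM.
Compound 3, `C/C(=N\NC(=S)Nc1ccccc1Cl)c1ccccn1`, gives 0.16 nM.

Compound 3 stands level with compound 1 and compound 2 at the digits shown. Compound 1 and compound 3 have the same atoms and bonds and differ only in how one double bond is drawn, and no change at the digits printed from compound 1 to compound 3 (within the scatter), which fits (the fact that compounds 1 and 3 differ only in the configuration as drawn).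

Compound 4, `C/C(=N\NC(=S)Nc1ccccc1I)c1ccccn1`, has not yet been measured in this assay. Against compound 3 the change is iodo in place of chloro on an aromatic carbon. Within the data shown here, no measured step exchanges one halogen for another; the single measured step concerned drawn configuration only, so it says nothing about the size of this change. Compound 4 is expected to stay close to compound 3. The expected step is no change at the digits printed from compound 3 to compound 4 (within the scatter). Compound 4 is estimated at 0.16 nM, within 0.05 nM to 0.5 nM.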

Compound 4, half-maximal inhibitory concentration: 4.1 nM
Estimate against measurement, compound 4: 26-fold (1.41 log units) below; measured number above the stated range.
By their numbers in this assay, from the lowest: compounds 1, 2 and 3 (each within the scatter of the next); then compound 4.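

In this assay, iodo in place of chloro on the aromatic carbon gives a 26-fold higher number from compound 3 to compound 4 (1.41 log units; beyond the scatter), so the read-out at this position depends on which halogen sits there, even though neither group carries a ring or a net charge. This is the first step shown that lies beyond the scatter; the earlier step changed only the configuration as drawn. Nothing at hand accounts for its size. As far as these compounds go, whether fluoro, bromo, methyl or an amine on this carbon would read closer to compound 3 or compound 4 remains open.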